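Removing the bromo from the shared core: compound 2 to compound 4

The source may hold more compounds than are shown below. What is called first, only, known or untested is meant among the compounds shown, and "the series" means these compounds.

Measured compounds:
compound 1 `N=c1c(C(N)=O)cc(Cl)cn1Cc1ccccc1` gives 30 nM
compound 2 `N=c1c(C(N)=O)cc(Br)cn1Cc1ccccc1` gives 160 nM
compound 3 `N=c1c(C(N)=O)cc(Cl)cn1Cc1ccccc1Cl` gives 39 nM

All three values come from an assay on CHO-K1 cells for displacement of a labelled ligand from Alpha-1D adrenergic receptor (Homo sapiens), read by scintillation counting, with a stated time of 60 min; a lower number here means a stronger inhibitor, a higher number a weaker inhibitor. Compound 2 stands highest of the three numbers: its nearest neighbour is compound 3, and the step of a 5.3-fold higher number from compound 1 to compound 2 (0.73 log units; beyond the scatter) sets it apart from compound 1 beyond the scatter. The step of a 1.3-fold higher number from compound 1 to compound 3 (0.11 log units; within the scatter), by contrast, stays within the scatter.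

Compound 4 `N=c1c(C(N)=O)cccn1Cc1ccccc1` is not yet measured. It differs from compound 2 by hydrogen in place of bromo on an aromatic carbon, two atoms from the ring nitrogen and meta to the carbamoyl group. Going by the values given here, only one measured step touches this position: a 5.3-fold higher number from compound 1 to compound 2 (0.73 log units; beyond the scatter), a modest loss when bromo replaced chloro. Among the compounds with values here, no measured compound carries hydrogen there, so the direction of the present change is not fixed by the data; the step of a 1.3-fold higher number from compound 1 to compound 3 (0.11 log units; within the scatter) concerns a different ring and bears on it only loosely.

Given the modest cost of the bromo in compound 2 shown by a 5.3-fold higher number from compound 1 to compound 2 (0.73 log units; beyond the scatter), compound 4 is expected to land near compound 2 or somewhat lower, an expected step of a 1.5-fold lower number from compound 2 to compound 4 (0.16 log units; within the scatter). The estimate for compound 4 in this assay is 110 nM, within a range of 30 nM to 450 nM.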

Compound 4, inhibition constant: 880 nM
Compound 4: the middle estimate sits 8.0-fold (0.90 log units) below what was measured, and the stated range ends below it.
By their numbers in this assay, from the lowest: compounds 1 and 3 (each within the scatter of the next); then compound 2; then compound 4.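

In this assay the position two atoms from the ring nitrogen now has three substituents to compare on the shared core, and hydrogen is the poorest of them: hydrogen in place of bromo gives a 5.5-fold higher number from compound 2 to compound 4 (0.74 log units; beyond the scatter), and hydrogen in place of chloro gives a 29-fold higher number from compound 1 to compound 4 (1.47 log units; beyond the scatter). Bromo therefore sits between the other two, so the earlier loss of a 5.3-fold higher number from compound 1 to compound 2 (0.73 log units; beyond the scatter) marked a less favourable halogen and gave no sign that the substituent could be dropped; from the lowest number, the order at this position runs chloro, bromo, hydrogen. No supporting measurement accounts for this order.

The compounds shown carry only chloro, bromo or hydrogen at this position, so the outcome with fluoro, methyl, methoxy, a nitrile or an amine there remains open. Compound 3 has no partner with bromo or hydrogen at this position, which leaves open whether the same order holds when the other ring carries a chloro.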